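From 4-methylphenyl to 4-fluorophenyl in the series

The source may hold more compounds than are shown below. What is called first, only, known or untested is meant among the compounds shown, and "the series" means these compounds.

In a functional assay on MDA-MB-231 cells (Homo sapiens) for antiproliferative activity, read by sulforhodamine B assay, with a stated time of 48 h (on this read-out lower numbers stand for stronger inhibition of growth and higher numbers for weaker inhibition of growth), compound 1 (`Cc1cc2c(cc1C)C(Cl)=C(c1nnc(Nc3ccccc3)s1)CCC2`) reads 5780 nM while compound 2 (`Cc1cc2c(cc1C)C(Cl)=C(c1nnc(-c3ccccc3)o1)CCC2`) reads 2760 nM and compound 3 (`Cc1ccc(-c2nnc(C3=C(Cl)c4cc(C)c(C)cc4CCC3)o2)cc1`) reads 1760 nM on the same scale. Compound 3 cannot be told apart from compound 2 on these numbers, whereas compound 1 sits higher than compound 3 by more than the scatter.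

The next step runs from compound 3 to compound 4 (`Cc1cc2c(cc1C)C(Cl)=C(c1nnc(-c3ccc(F)cc3)o1)CCC2`), which carries fluoro in place of methyl on an aromatic carbon of a six-membered aromatic ring of carbon only, para to a large group. The same difference reads 4-methylphenyl to 4-fluorophenyl.

Among the measured compounds shown here, one measured step bears on this change. It is a 1.6-fold lower number from compound 2 to compound 3 (0.20 log units; within the scatter) for methyl in place of hydrogen on an aromatic carbon, and it stays within the scatter. For the measured compounds named here, no fluoro compound has been measured, so the data give no firm direction for the swap, and no shift beyond the scatter is expected in this assay here. The expected step is a 1.3-fold higher number from compound 3 to compound 4 (0.10 log units; within the scatter) and this estimate stays within the scatter. In this assay compound 4 is estimated at 2200 nM with an expected range from 1100 nM to 4400 nM for now.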

Compound 4, concentration for 50% growth inhibition: 1400 nM
Compound 4: the middle estimate sits 1.6-fold (0.20 log units) above what was measured, within the range that was stated.
By their numbers in this assay, from the lowest: compounds 4, 3 and 2 (each within the scatter of the next); then compound 1.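

In this assay, the 4-fluorophenyl group gives a third substituent reading on an aromatic carbon of the six-membered ring, para to a large group: a 1.3-fold lower number from compound 3 to compound 4 (0.10 log units; within the scatter) for fluoro in place of methyl, and a 2.0-fold lower number from compound 2 to compound 4 (0.29 log units; within the scatter) for fluoro in place of hydrogen, both within the scatter. Together with a 1.6-fold lower number from compound 2 to compound 3 (0.20 log units; within the scatter), also within the scatter, this means that hydrogen, methyl and fluoro at this position cannot be told apart on these numbers, so the series so far shows no readable response to a change of this size here. No supporting evidence bears on this result, and the flat reading remains an observation without an explanation.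

Still open, going by these compounds, is whether a carboxylic acid, an amine or a longer chain such as n-butyl at this position would move the number beyond the scatter. Also open, on these data alone, is whether methoxy or trifluoromethyl in the same place would stay as flat as hydrogen, methyl and fluoro, and whether the same flat reading would hold in another cell line.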